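Shifting the chain on the aromatic nitrogen of the core

The compounds below may be only part of what the source reports. "The series", "measured", "known", "first", "only" and "open" are said of these compounds alone.

Compound 1 `CN1CCN(c2nc3ccccc3n2-c2ccccc2)CC1` gives 760 nM in a functional assay on ileum for inhibition of histamine H1 receptor (Cavia porcellus); on this read-out higher numbers stand for weaker inhibition and lower numbers for stronger inhibition. Compound 2 `COCCn1c(N2CCN(C)CC2)nc2ccccc21` gives 13 nM and stands lowest of the two numbers; the step of a 58-fold lower number from compound 1 to compound 2 (1.77 log units; beyond the scatter) is the only one known. Compound 3 `CCCC(C)Cn1c(N2CCN(C)CC2)nc2ccccc21` differs from compound 2 by 1-methylbutyl in place of methoxymethyl on a saturated chain carbon bound to an aromatic nitrogen. That step shows only that a chain on this nitrogen can be favoured over phenyl; no comparison separates the ether chain from a plain branched one. Compound 3 is therefore expected near compound 2, with a step of a 2.3-fold higher number from compound 2 to compound 3 (0.36 log units; beyond the scatter) in this assay, the estimate being 30 nM within 8 nM to 120 nM.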

Compound 3, half-maximal inhibitory concentration: 500 nM
Compound 3: middle estimate off by 17-fold (1.22 log units), on the low side, and the stated range ends below it.
By their numbers in this assay, from the lowest: compound 2; then compounds 3 and 1 (each within the scatter of the next).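

In this assay, a chain on the aromatic nitrogen is not enough in itself: a 38-fold higher number from compound 2 to compound 3 (1.59 log units; beyond the scatter) sets 2-methylpentyl far from 2-methoxyethyl, so the nature of the chain matters at this place. The plain branched chain also cannot be told apart from phenyl, with a 1.5-fold lower number from compound 1 to compound 3 (0.18 log units; within the scatter) separating them. Nothing at hand explains the gap between the two chains.

The two chains differ in both the ether oxygen and the branching, and the compounds shown do not separate these. A straight pentyl chain or a 2-hydroxyethyl chain on this nitrogen remains an open comparison.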